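Adding an amino group to the anilide of compound 3

The source may report more compounds than this note shows. Statements on the series, on what has been measured and on what is new or still open speak of the compounds shown alone.

Compound 3 `O=C(Nc1ccccc1)c1c(O)c2cccnc2n(-c2ccccc2)c1=O` stands lowest of the three measured compounds in a functional assay on the whole organism for inhibition, with Rattus norvegicus as the target, read by cytopathic effect and paw edema, at a dose of 100 mg/kg by the oral route; on this read-out higher numbers stand for more inhibition at the one dose given (going by the name of the read-out) and lower numbers for less inhibition: compound 3 gives -15%. The other two share its core but carry a different group on the carbonyl carbon. Compound 1 `CCOC(=O)c1c(O)c2cccnc2n(-c2ccccc2)c1=O` gives 15.5%, and compound 2 `CCCCNC(=O)c1c(O)c2cccnc2n(-c2ccccc2)c1=O` gives 20.4%. The steps that lead to compound 3 are both large: a number 30.5 percentage points lower from compound 1 to compound 3 (beyond the scatter) and a number 35.4 percentage points lower from compound 2 to compound 3 (beyond the scatter). Among the compounds with values here, the one step not involving compound 3, a number 4.9 percentage points higher from compound 1 to compound 2 (within the scatter), stays within the scatter.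

Compound 4 `Nc1ccc(NC(=O)c2c(O)c3cccnc3n(-c3ccccc3)c2=O)cc1` differs from compound 3 in one place: amino in place of hydrogen on an aromatic carbon. Within the data shown here, none of the measured steps changes a substituent on the phenyl ring of the anilide, so no measured step bears directly on this change; the measured steps only show that the anilide itself lowered the number sharply. Without a comparable precedent, a step of no size beyond the scatter is expected, a number 10 percentage points higher from compound 3 to compound 4 (within the scatter). Compound 4 is therefore estimated at -5%, within a range from -30% to 20%.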

Compound 4, a percentage reported as inhibition, in the whole organism at one dose (the size of the read-out at that dose, not a potency): 0%
The estimate for compound 4 lay 5 percentage points below the measured number; low and high end bracket the measured number.
By their numbers in this assay, from the lowest: compound 3; then compound 4; then compounds 1 and 2 (each within the scatter of the next).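

Within the data shown here, putting amino on this aromatic carbon, para to a large group, gives a step beyond the scatter, with a number 15 percentage points higher from compound 3 to compound 4 (beyond the scatter) as the result, so this place on the anilide's phenyl ring can change the read-out, which no earlier step could show. The change recovers only part of the ground, since there is still a number 20.4 percentage points lower from compound 2 to compound 4 (beyond the scatter) and also a number 15.5 percentage points lower from compound 1 to compound 4 (beyond the scatter) on the other side of the comparison, both beyond the scatter. Nothing at hand explains why amino has this effect.

From the compounds shown here alone, it remains open whether the gain is specific to amino, or whether a hydroxyl group, a methoxy group or a chlorine atom on the same carbon would give a similar step. Going by these compounds, the effect of amino on any other carbon of that ring also remains open.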